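The source may hold more compounds than are shown below. What is called first, only, known or untested is meant among the compounds shown, and "the series" means these compounds.

Working notes on the coumarin-chalcone series. Within the data shown here, compound 2, `COc1ccc(/C=C/c2cc(OC)cc(OC)c2/C=C/C(=O)c2cc3cc(C)ccc3oc2=O)cc1`, is the only member with a numeric read-out: in an assay on isolated protein for inhibition of Amine oxidase [flavin-containing] A (Homo sapiens), read by fluorescence, with a stated time of 15 min (a higher number here means a weaker inhibitor, a lower number a stronger inhibitor), compound 2 gives 30400 nM. Compound 1, `COc1ccc(/C=C/c2cc(OC)cc(OC)c2/C=C/C(=O)c2cc3ccc(Cl)cc3oc2=O)cc1`, is reported in this assay as a limit, > 60000 nM, and no number. Among the measured compounds shown here, the one measured step, an at least 1.9-fold lower number from compound 1 to compound 2 (0.29 log units; that floor lies within the scatter), therefore rests on a limit at one end; the line the limit of > 60000 nM in this assay, at which 1 of the 2 values shown sits, marks that limit, and the floor of the step lies within the scatter, so nothing firm follows from it.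

Compound 3, `COc1ccc(/C=C/c2cc(OC)cc(OC)c2/C=C/C(=O)c2cc3cc(Br)ccc3oc2=O)cc1`, differs from compound 2 by bromo in place of methyl on an aromatic carbon. For the measured compounds named here, no measured step exchanges methyl for bromo, so the step from compound 1 to compound 2 is the nearest guide: it replaces a group carrying chloro with a group carrying methyl and gives a number at least at the floor of the scatter in the direction of stronger inhibition. Swapping methyl back out for a halogen is expected to move in the opposite direction, by a 1.6-fold higher number from compound 2 to compound 3 (0.22 log units; within the scatter), with a real chance that only a limit is returned. Compound 3 is estimated at 50000 nM, within 20000 nM to 120000 nM.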

Compound 3, half-maximal inhibitory concentration: 12100 nM
Compound 3: the middle estimate sits 4.1-fold (0.62 log units) above what was measured, outside the stated range (below it).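

Bromo in place of methyl on this aromatic carbon gives a 2.5-fold lower number from compound 2 to compound 3 (0.40 log units; beyond the scatter), the first step in the series with numbers at both ends and the first to lie beyond the scatter, and it runs towards stronger inhibition in this assay. A halogen on the core therefore does not by itself mark the weaker end of the series, and the halogen-bearing groups on the carbonyl carbon are not interchangeable, as the comparison across them gives an at least 4.9-fold lower number from compound 1 to compound 3 (0.69 log units; beyond the scatter). Compound 1 is a limit and not a number, so that step gives only a floor: the limit of > 60000 nM in this assay, at which 1 of the 3 values shown sits.

The compounds shown leave open how bromo compares with chloro, fluoro or iodo on this same aromatic carbon, as the step between compound 1 and compound 3 exchanges the whole group on the carbonyl carbon and does not isolate the halogen. Also open, on these data alone, is whether a nitrile, an amine or a carboxylic acid on this carbon would match compound 3, and whether the gain from bromo over methyl holds when the rest of the shared core changes.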